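A Methyl in Place of Chlorine on the Carboxyphenyl Ether

A few compounds are considered here, and "the series" means these few. Any claim that something is new, unique, unknown or untested is made for them only; others in the source may bear on it.

Compound 1, `Cc1c(OCCCCOc2ccc(C(=O)O)cc2)ccc(C(=O)CC2CCCC2)c1O`, in an assay on HEK293 cells for positive allosteric modulation of metabotropic glutamate receptor 3 (Rattus norvegicus), read by thallium flux, with a stated time of 2.5 min (a lower number here means that less compound is needed, a higher number that more compound is needed for the effect), gives > 10000 nM; this is a limit of the assay rather than a number.
Compound 2, `Cc1c(OCCCCOc2ccc(C(=O)O)c(Cl)c2)ccc(C(=O)CC2CCCC2)c1O`, in this assay gives 2250 nM.

Compound 2 holds the only number shown; the other value is a limit. Within the data shown here, the single measured step, an at least 4.4-fold lower number from compound 1 to compound 2 (0.64 log units; beyond the scatter), shows that putting a chlorine where hydrogen stood gave a clearly stronger effect, though its size is only bounded because the limit of > 10000 nM in this assay, at which 1 of the 2 values shown sits, caps what compound 1 can show. Compound 3, `Cc1cc(C(=O)O)ccc1OCCCCOc1ccc(C(=O)CC2CCCC2)c(O)c1C`, differs from compound 2 by 4-carboxy-2-methylphenyl in place of 4-carboxy-3-chlorophenyl on an oxygen on a saturated carbon. Among the measured compounds shown here, no measured step tests this change directly; the chloro step bears on it only loosely, as a substituent is kept on the ring but changed in kind and in place. For compound 3 a somewhat weaker effect is expected, a 2.2-fold higher number from compound 2 to compound 3 (0.35 log units; beyond the scatter), with a fair chance that only a limit is reported. The estimate for compound 3 in this assay is 5000 nM, ranging from 1500 nM to 20000 nM.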

Compound 3, half-maximal effective concentration: > 10000 nM
Compound 3: only a limit was reported; the forecaster's own chance of this, stated with the estimate: 40%; at least 2.0-fold (0.30 log units) between middle value and limit.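

In this assay, the change to 4-carboxy-2-methylphenyl brings an at least 4.4-fold higher number from compound 2 to compound 3 (0.64 log units; beyond the scatter), so a substituent on this ring does not by itself keep a measurable effect. The value of compound 3, > 10000 nM, is a limit of the assay and not a number. The step from compound 1 to compound 3 cannot be read, and the loss from compound 2 has only a lower bound, because both compound 1 and compound 3 sit at the same limit: the limit of > 10000 nM in this assay, at which 2 of the 3 values shown sit.

This change alters both the kind of substituent and its place on the ring, so the compounds shown cannot separate the two. From the compounds shown here alone, it also stays open whether a methyl, fluoro or methoxy group in the exact place of the chlorine in compound 2 would hold the effect.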